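A few compounds are considered here, and "the series" means these few. Any claim that something is new, unique, unknown or untested is made for them only; others in the source may bear on it.

Measured compounds:
- Compound 1, `COc1ccccc1C1CCN(CC(=O)Nc2cccc(C)c2)CC1`: 43%
- Compound 2, `Cc1cccc(NC(=O)CN2CCC(c3cccc(O)c3)CC2)c1`: 66%
- Compound 3, `Cc1cccc(NC(=O)CN2CCC(c3ccc(O)cn3)CC2)c1`: 83%

In a functional assay on HEK293 cells for agonist activity at D(4) dopamine receptor (Homo sapiens), read by FLIPR (a lower number here means a smaller maximal response, a higher number a larger maximal response), compound 3 stands at the top of the three numbers. Its nearest neighbour is compound 2, a number 17 percentage points higher from compound 2 to compound 3 (beyond the scatter), and the furthest is compound 1, a number 40 percentage points higher from compound 1 to compound 3 (beyond the scatter); both steps lie beyond the scatter. Compound 2 itself sits above compound 1, a number 23 percentage points higher from compound 1 to compound 2 (beyond the scatter).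

Compound 4, `Cc1cccc(NC(=O)CN2CCC(c3cccc(C#N)n3)CC2)c1`, has not yet been measured. It differs from compound 3 in one place: 6-cyanopyridin-2-yl in place of 5-hydroxypyridin-2-yl on a saturated ring carbon.

Going by the values given here, the steps that bear on this change are those into compound 3, since they describe what the 5-hydroxypyridin-2-yl group contributed: a large rise from compound 1 and a modest rise from compound 2. Among the compounds with values here, compound 4 keeps a pyridin-2-yl ring but gives up the hydroxyl group, the only hydrogen-bond donor counted in the leaving group, and compound 1, the one compound here without such a donor, shows the lowest number. Compound 4 is therefore expected to fall back from compound 3, with an estimated step of a number 33 percentage points lower from compound 3 to compound 4 (beyond the scatter) in this assay. The estimate for compound 4 is 50%, in a range from 25% to 75%.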

Compound 4, largest response reached (reported as efficacy), in percent of the reference or control that the assay uses: 42%
Compound 4: the middle estimate sits 8 percentage points above what was measured, within the range that was stated.
By their numbers in this assay, from the lowest: compounds 4 and 1 (each within the scatter of the next); then compound 2; then compound 3.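

In this assay, the step of a number 41 percentage points lower from compound 3 to compound 4 (beyond the scatter) shows that keeping a pyridin-2-yl ring at this position, on a saturated ring carbon three ring bonds from the ring nitrogen, does not by itself preserve the maximal response once 6-cyanopyridin-2-yl replaces 5-hydroxypyridin-2-yl. The ring type does not set the order among these compounds either: the step of a number 24 percentage points lower from compound 2 to compound 4 (beyond the scatter) places the pyridine-bearing compound 4 under the phenyl-bearing compound 2, while the step of a number 1 percentage points lower from compound 1 to compound 4 (within the scatter) leaves compound 4 indistinguishable from the 2-methoxyphenyl compound. Across these four compounds, the two with a hydroxyl group, compound 2 and compound 3, give the higher numbers, and neither compound without one goes against this.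

Because this change removes the hydroxyl group, adds a nitrile and moves the substituent to another ring position all at once, these compounds cannot separate those three changes, and 5-cyanopyridin-2-yl, 6-hydroxypyridin-2-yl or 5-aminopyridin-2-yl groups would be needed to do so. No measurement is available here that explains the size of this fall.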